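Swapping chloro for bromo on a shared core

The source may report more compounds than this note shows. Statements on the series, on what has been measured and on what is new or still open speak of the compounds shown alone.

Of the compounds shown here, three sharing one core have been tested in a functional assay on UACC-257 cells (Homo sapiens) for inhibition, read by sulforhodamine B assay, with a stated time of 48 h, tested at 10 uM; on this read-out higher numbers stand for more inhibition at the one concentration tested (going by the name of the read-out) and lower numbers for less inhibition. Compound 1 `c1ccc(-c2cn3ccnc3c(-c3ccc4ncn(C5CCCCC5)c4c3)n2)cc1` gives 5.22%. Compound 2 `COc1ccc(-c2cn3ccnc3c(-c3ccc4ncn(C5CCCCC5)c4c3)n2)cc1`, which carries a methoxy group, gives 26.3%. Compound 3 `Clc1ccc(-c2cn3ccnc3c(-c3ccc4ncn(C5CCCCC5)c4c3)n2)cc1`, with a chloro group, gives 5.44%. Compound 3 therefore stands close to compound 1, the two numbers lying within the usual scatter, while its gap to compound 2 is larger: the change a number 20.9 percentage points lower from compound 2 to compound 3 (beyond the scatter) lies beyond the scatter.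

Compound 4 `Brc1ccc(-c2cn3ccnc3c(-c3ccc4ncn(C5CCCCC5)c4c3)n2)cc1` differs from compound 3 in one place: bromo in place of chloro on an aromatic carbon. The step that bears most on this is a number 0.2 percentage points higher from compound 1 to compound 3 (within the scatter), which shows that putting a chloro group on that carbon left the number essentially where it was. For the measured compounds named here, no step involving a bromo group has been measured, so the outcome rests on that single comparison. The expectation is that compound 4 will show no change beyond the scatter, an estimated step of a number 2.6 percentage points higher from compound 3 to compound 4 (within the scatter). For compound 4 the estimated value in this assay is 8%, with a likely range from -4% to 22%.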

Compound 4, a percentage reported as inhibition, at one concentration (the size of the read-out at that concentration, not a potency): 7.3%
Compound 4: the middle estimate sits 0.7 percentage points above what was measured, within the range that was stated.
By their numbers in this assay, from the lowest: compounds 1, 3 and 4 (each within the scatter of the next); then compound 2.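

In this assay, the change from chloro to bromo gives a number 1.9 percentage points higher from compound 3 to compound 4 (within the scatter), and placing bromo on the carbon that bears hydrogen in compound 1 gives a number 2.1 percentage points higher from compound 1 to compound 4 (within the scatter), so this second halogen, like chloro, leaves the number within the scatter of the unsubstituted compound. Methoxy remains the only group shown here that stands apart at this position, with bromo in its place giving a number 19 percentage points lower from compound 2 to compound 4 (beyond the scatter), although this contrast rests on compound 2 alone. Nothing available explains the difference between methoxy and the other groups.

The compounds shown leave open whether a hydroxyl group, an ethoxy group or an amine on the same carbon would behave like methoxy or like the two halogens. They also leave open how these compounds would compare at other concentrations, since a single concentration gives no measure of potency.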